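Hydroxy to methoxy on two cores: an expected step

The source may hold more compounds than are shown below. What is called first, only, known or untested is meant among the compounds shown, and "the series" means these compounds.

Compound 1 `O=C(/C=C/c1ccc(O)cc1)c1ccc2occc2c1O` and compound 3 `O=C(/C=C/c1ccc(O)cc1)c1cc2ccoc2cc1O` are built from the same atoms joined differently; the difference between the two cores is not broken down here. In an assay on isolated protein for inhibition of lysosomal alpha-glucosidase (Rattus norvegicus), read by spectrophotometry, with a stated time of 5 min, tested at 25 ug/mL (on this read-out higher numbers stand for more inhibition at the one concentration tested (going by the name of the read-out) and lower numbers for less inhibition), compound 1 gives 65.7%, the highest of the three measured numbers, while compound 3 gives 8.77%. Compound 2 `COc1ccc(/C=C/C(=O)c2cc3ccoc3cc2O)cc1` carries on the core of compound 3 the change (methyl in place of hydrogen on an oxygen on an aromatic ring); in this assay compound 2 gives 48.9%, and the step is a number 40.1 percentage points higher from compound 3 to compound 2 (beyond the scatter). Compound 4 `COc1ccc(/C=C/C(=O)c2ccc3occc3c2O)cc1` carries the same change on the core of compound 1: methyl in place of hydrogen on an oxygen on an aromatic ring. The cores differ, so the earlier step is a guide, not a rule. The step from compound 1 to compound 4 is expected to be a number 6.3 percentage points higher from compound 1 to compound 4 (within the scatter), smaller than the earlier one, because compound 1 already stands at 65.7% and the same change on the other core gave a number 40.1 percentage points higher from compound 3 to compound 2 (beyond the scatter). Compound 4 is expected to give 72%, likely between 48% and 92%.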

Compound 4, a percentage reported as inhibition, at one concentration (the size of the read-out at that concentration, not a potency): 94.8%
For compound 4 the middle estimate is 22.8 percentage points below the measured one, outside the stated range (above it).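

Hydroxy to methoxy raises the number on the core of compound 1 as well, with a number 29.1 percentage points higher from compound 1 to compound 4 (beyond the scatter), so the direction of the step carries over between the two cores shown. The two steps cannot be told apart in size: the same change on two cores in this assay, a number 40.1 percentage points higher (beyond the scatter) from compound 3 to compound 2 and a number 29.1 percentage points higher (beyond the scatter) from compound 1 to compound 4, 11 percentage points apart, within the scatter of two such steps. This is one matched pair on each of two cores and not a rule for the series, and it gives no reason for the rise, while a reading at one concentration in this assay does not give potency.

The compounds shown leave open how a longer chain on that oxygen, such as ethyl, or an amine in place of the methoxy would read. They also leave open the effect of the same change on the other hydroxy, the one on the core.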